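The source may hold more compounds than are shown below. What is called first, only, known or untested is meant among the compounds shown, and "the series" means these compounds.

Measured so far in an ADME assay on MT4 cells (Homo sapiens) for cytotoxicity, read by MTT assay, with a stated time of 5 days; on this read-out higher numbers stand for lower toxicity in this test and lower numbers for higher toxicity in this test:
- compound 1 `COc1cc(Cc2cnc(/N=C3\C(=O)N(CN4CCN(C)CC4)c4ccc(Cl)cc43)nc2N)cc(OC)c1OC`: 80.7 ug/mL
- compound 2 `COc1cc(Cc2cnc(/N=C3\C(=O)N(CN4CCN(c5ccc(Cl)cc5)CC4)c4ccc(Cl)cc43)nc2N)cc(OC)c1OC`: 38.6 ug/mL

Going by the values given here, compound 2 holds the lower of the two numbers in this assay; the only measured step, a 2.1-fold lower number from compound 1 to compound 2 (0.32 log units; beyond the scatter), concerns the group on the amine nitrogen in the ring, not the aromatic halogen.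

Compound 3 `COc1cc(Cc2cnc(/N=C3\C(=O)N(CN4CCN(c5ccc(F)cc5)CC4)c4ccc(Cl)cc43)nc2N)cc(OC)c1OC` differs from compound 2 by fluoro in place of chloro on an aromatic carbon. Among the compounds with values here, no measured step bears on this change, so the expectation rests on compound 2 alone. The step is expected to stay within the scatter, a 1.2-fold higher number from compound 2 to compound 3 (0.07 log units; within the scatter). Compound 3 is therefore estimated at 45 ug/mL, range 22 ug/mL to 95 ug/mL.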

Compound 3, half-maximal cytotoxic concentration: 65.6 ug/mL
Beside the measured number, compound 3's estimate is 1.5-fold (0.16 log units) below it, within the range that was stated.
By their numbers in this assay, from the lowest: compounds 2, 3 and 1 (each within the scatter of the next, the first and the last beyond it).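

In this assay, fluoro in place of chloro on an aromatic carbon gives a 1.7-fold higher number from compound 2 to compound 3 (0.23 log units; within the scatter) and so leaves no readable difference at this place. The 4-fluorophenyl group gives a 1.2-fold lower number from compound 1 to compound 3 (0.09 log units; within the scatter) against methyl on the ring amine nitrogen, whereas the 4-chlorophenyl group gave a 2.1-fold lower number from compound 1 to compound 2 (0.32 log units; beyond the scatter) and stood beyond the scatter. Nothing available explains why the two halogens part in this way.

Open, from the compounds shown here alone, is how bromo, methoxy or an amine at this place on the aromatic ring would read. Also open, going by these compounds, is whether a carboxylic acid there would leave the number within the scatter.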